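Methoxy to Ethoxy at the Edge of Detection

A few compounds are considered here, and "the series" means these few. Any claim that something is new, unique, unknown or untested is made for them only; others in the source may bear on it.

Compound 1, `CCOc1ccc(F)cc1C(C)NC(=O)NS(=O)(=O)c1ccc(Cl)cc1`: > 300000 nM
Compound 2, `COc1ccc(Cl)cc1C(C)NC(=O)NS(=O)(=O)c1ccc(Cl)cc1`: > 300000 nM

Both compounds were tested in a functional assay on thoracic aorta (Rattus norvegicus, strain Wistar), with a stated time of 15 min; on this read-out lower numbers stand for an effect already at smaller amounts and higher numbers for an effect only at larger amounts of compound. For compound 1 the value > 300000 nM is a limit of the assay and not a number. For compound 2 the value > 300000 nM is likewise a limit of the assay, not a measured number. Compound 2 therefore cannot be placed on a scale against anything else: it sits at the limit of > 300000 nM in this assay, at which 2 of the 2 values shown sit, and so does every other value shown. Nothing here separates the two compounds from each other.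

Compound 3, `CCOc1ccc(Cl)cc1C(C)NC(=O)NS(=O)(=O)c1ccc(Cl)cc1`, is not yet measured. It differs from compound 2 by a single change, (methyl in place of hydrogen on a saturated chain carbon bound to an oxygen on an aromatic ring). The same change, read one bond further out, is methoxy to ethoxy. Compound 1 already carries an ethoxy on the same side of the core and gives a limit too. Going by the values given here, with no measured step to lean on and both neighbours at the limit, the step from compound 2 to compound 3 is expected to be a step that the limit leaves unreadable from compound 2 to compound 3, that is, nothing beyond the usual scatter. Compound 3 is estimated to give 500000 nM in this assay, within 150000 nM to 3000000 nM, most likely again reported only as a limit.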

Compound 3, half-maximal effective concentration: 281000 nM
Compound 3: middle estimate off by 1.8-fold (0.25 log units), on the high side; the measured number falls inside the stated range.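

In this assay, going by these compounds alone, compound 3 gives 281000 nM, the only real number in this small set, which shows that the combination of ethoxy and chloro on this ring can register an effect in this test, though only at very large amounts of compound. Methyl in place of hydrogen on a saturated chain carbon bound to an oxygen on an aromatic ring, which is methoxy to ethoxy, comes with an at least 1.0-fold lower number from compound 2 to compound 3 (0.02 log units; that floor lies within the scatter), and chloro in place of fluoro on an aromatic carbon comes with an at least 1.0-fold lower number from compound 1 to compound 3 (0.02 log units; that floor lies within the scatter). Neither change can be given a true size, and each may be negligible or larger, because the starting point of each step is only a limit: the limit of > 300000 nM in this assay, at which 2 of the 3 values shown sit.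

The compounds shown do not tell whether a longer chain such as propoxy, or an amine in the place of the ethoxy, would bring the number down further. They also leave open whether bromo in the place of the chloro on this ring would keep a measurable value, and whether ethoxy and chloro each matter on their own.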